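Benzoyl in place of the chloro trifluoromethyl phenylamino group

A few compounds are considered here, and "the series" means these few. Any claim that something is new, unique, unknown or untested is made for them only; others in the source may bear on it.

In a functional assay on RXF 393 cells (Homo sapiens) for inhibition, read by sulforhodamine B assay, with a stated time of 48 h (on this read-out higher numbers stand for weaker inhibition of growth and lower numbers for stronger inhibition of growth), compound 3 `COc1cc(-c2nn(-c3cccc(NC(=O)Nc4ccc(Cl)c(C(F)(F)F)c4)c3)cc2-c2ccncc2)ccc1Cl` gives 1180 nM, the highest number of the three measured analogues; its nearest neighbour is compound 1 `COc1cc(-c2nn(-c3cccc(NC(=O)c4cccc(C(F)(F)F)c4)c3)cc2-c2ccncc2)ccc1Cl`, which gives 811 nM, and compound 2 `COc1cc(-c2nn(-c3cccc(NC(=O)Nc4cccc(C(F)(F)F)c4)c3)cc2-c2ccncc2)ccc1Cl` gives 777 nM, both within the scatter of compound 3. Compound 4 `COc1cc(-c2nn(-c3cccc(NC(=O)c4ccccc4)c3)cc2-c2ccncc2)ccc1Cl` is not yet measured. The change from compound 3 to compound 4 is phenyl in place of (4-chloro-3-(trifluoromethyl)phenyl)amino on a carbonyl carbon. Within the data shown here, two measured steps bear on it: a 1.5-fold higher number from compound 1 to compound 3 (0.16 log units; within the scatter) shows that putting the (4-chloro-3-(trifluoromethyl)phenyl)amino group in place of the 3-(trifluoromethyl)phenyl group on the carbonyl carbon moved the number only within the scatter, and a 1.5-fold higher number from compound 2 to compound 3 (0.18 log units; within the scatter) shows the same for the chloro in place of hydrogen. Among the measured compounds shown here, no step in this set removes the trifluoromethyl group itself, so that part of the change has no measured precedent. Taken together, compound 4 is expected to land close to compound 1, with a 1.3-fold lower number from compound 3 to compound 4 (0.12 log units; within the scatter) expected to stay within the scatter and no direction claimed. The estimate for compound 4 in this assay is 900 nM, with a range from 400 nM to 2500 nM.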

Compound 4, concentration for 50% growth inhibition: 646 nM
Beside the measured number, compound 4's estimate is 1.4-fold (0.14 log units) above it; measured number inside the range.
By their numbers in this assay, from the lowest: compounds 4, 2, 1 and 3 (each within the scatter of the next).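

Phenyl on the carbonyl carbon is now compared directly with both substituted phenylamino groups and with 3-(trifluoromethyl)phenyl. In this assay, all three changes stay within the scatter: a 1.8-fold lower number from compound 3 to compound 4 (0.26 log units; within the scatter), a 1.2-fold lower number from compound 2 to compound 4 (0.08 log units; within the scatter) and a 1.3-fold lower number from compound 1 to compound 4 (0.10 log units; within the scatter). The step from compound 1 to compound 4 supplies the precedent that was missing for removing trifluoromethyl, and compound 4 shows that the series keeps its growth-inhibition readout on this carbonyl carbon with neither the trifluoromethyl group, the chloro group nor the amino nitrogen; no reason for this flat response can be given from the data at hand.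

The compounds shown leave open whether any group on this carbonyl carbon can move the number beyond the scatter, as all four compounds carry a six-membered aromatic carbon ring there. A phenyl ring bearing a dimethylamino group or a carboxylic acid, or a longer alkyl chain in place of the ring, would test the limits of this tolerance in this assay.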